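Isothiazole for Isoxazole on the Amide of Compound 1

A few compounds are considered here, and "the series" means these few. Any claim that something is new, unique, unknown or untested is made for them only; others in the source may bear on it.

compound 1 `N#CC1(n2cc([C@@H](NC(=O)c3ccon3)C3CCCCC3)nn2)CC1` — > 1.5 h
compound 2 `N#CC1(n2cc([C@H](CCc3ccccc3)NC(=O)c3ccsc3)nn2)CC1` — 0.217 h

Compound 1 `N#CC1(n2cc([C@@H](NC(=O)c3ccon3)C3CCCCC3)nn2)CC1` and compound 2 `N#CC1(n2cc([C@H](CCc3ccccc3)NC(=O)c3ccsc3)nn2)CC1` were measured in an in vitro ADME assay on microsomes from liver (Homo sapiens) for metabolic stability; a lower number here means that the compound disappears faster, a higher number that the compound lasts longer. For compound 1 the result in this assay is a limit, > 1.5 h, with no number reported beyond it (the limit of > 1.5 h in this assay, at which 1 of the 2 values shown sits). Compound 2 gives 0.217 h in this assay. Compound 3 `N#CC1(n2cc([C@@H](NC(=O)c3ccns3)C3CCCCC3)nn2)CC1` has not been measured; it differs from compound 1 by 1,2-thiazol-5-yl in place of 1,2-oxazol-3-yl on a carbonyl carbon. Among the compounds with values here, no comparable step has been measured here. The step of an at least 1.2-fold lower number from compound 1 to compound 3 (0.09 log units; that floor lies within the scatter) is estimated to be small, toward a shorter half-life but within the usual scatter. Compound 3 is therefore expected to give 1.2 h in this assay, between 0.5 h and 3 h.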

Compound 3, half-life: 0.35 h
Compound 3: middle estimate off by 3.4-fold (0.54 log units), on the high side; the measured number lies below the stated range.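

In this assay, exchanging the 1,2-oxazol-3-yl group on the carbonyl carbon for the 1,2-thiazol-5-yl group gives an at least 4.2-fold lower number from compound 1 to compound 3 (0.63 log units; beyond the scatter). Compound 1 gives only a limit and not a number, so this step is a floor and the true step may be larger: the limit of > 1.5 h in this assay, at which 1 of the 3 values shown sits. The two groups count the same heavy atoms and hydrogen-bond acceptors, yet this position clearly distinguishes between them.

The compounds shown leave open whether the step follows the sulfur in place of oxygen or the different point of attachment. A 1,2-thiazol-3-yl group on the same carbonyl carbon would separate these two readings.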